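Cytotoxicity notes on the urea series: compound 4

A few compounds are considered here, and "the series" means these few. Any claim that something is new, unique, unknown or untested is made for them only; others in the source may bear on it.

Three ureas on the shared core have been measured in an ADME assay on HepG2 cells (Homo sapiens) for cytotoxicity, with a stated time of 72 h; on this read-out higher numbers stand for an effect only at larger amounts of compound and lower numbers for an effect already at smaller amounts. Compound 1 `COC(=O)c1ccc(NC(=O)Nc2cc(C)nc3ccccc23)cc1` gives 20000 nM; compound 2 `Cc1cc(NC(=O)Nc2ccc(F)c(F)c2)c2ccccc2n1` gives 21000 nM; compound 3 `Cc1cc(NC(=O)Nc2ccc(Cl)c(Cl)c2)c2ccccc2n1` gives 17000 nM. Compound 1 thus sits second highest of the three numbers, but all three lie within the scatter of one another, so no order among them can be read. Compound 4 `Cc1cc(NC(=O)Nc2ccc(OC(F)(F)F)cc2)c2ccccc2n1` is the next case: relative to compound 1 the change is trifluoromethoxy in place of methoxycarbonyl on an aromatic carbon. Among the compounds with values here, no measured pair isolates that change, and the three measured compounds show no movement beyond the scatter for the variations they do carry, so no step beyond the scatter is expected here. The number for compound 4 is estimated at 19000 nM, with a range of 9000 nM to 40000 nM, an expected step of a 1.1-fold lower number from compound 1 to compound 4 (0.02 log units; within the scatter).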

Compound 4, half-maximal effective concentration: 15000 nM
Beside the measured number, compound 4's estimate is 1.3-fold (0.10 log units) above it, and the stated range covers the measured number.
By their numbers in this assay, from the lowest: compounds 4, 3, 1 and 2 (each within the scatter of the next).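

In this assay, trifluoromethoxy in place of methoxycarbonyl on an aromatic carbon, para to a large group, gives a 1.3-fold lower number from compound 1 to compound 4 (0.12 log units; within the scatter). Within the data shown here, this is the first measured pair that differs in one place, and it shows that these two groups cannot be told apart at this position on this read-out. No other data bear on this result. Going by these compounds, it remains open whether an amine or a carboxylic acid at this position would give a step beyond the scatter. On these data alone, whether changes to the shared core would do so also remains open.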